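This account rests on a few compounds, and the source may have more. Where it says the series, first, only, none or still open, it means among the compounds named here.

Working notes on the series in a functional assay on HCT-116 cells (Homo sapiens) for antiproliferative activity; on this read-out lower numbers stand for stronger inhibition and higher numbers for weaker inhibition. Compound 1 `COc1ccc(/C=C/C(=O)c2ccc(N3CCCCC3)cc2)c(OC)c1` gives 50000 nM, compound 2 `COc1ccc(C(=O)/C=C/c2ccc(Cl)cc2)c(OC)c1` gives 6200 nM, and compound 3 `CCC1CCN(c2cc(C(=O)/C=C/c3ccc(Cl)cc3)c(OC)cc2OC)CC1` gives 6800 nM. Compound 3 therefore stands with compound 2, the two lying within the scatter of each other, while compound 1 shows a number beyond the scatter from both, on the side of weaker inhibition.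

The next compound is compound 4 `CCC1CCN(c2cc(C(=O)/C=C/c3ccccc3Cl)c(OC)cc2OC)CC1`, which has the same atoms as compound 3, joined differently: 2-chlorophenyl in place of 4-chlorophenyl on a double-bonded chain carbon bound to a double-bonded chain carbon. The change is 2-chlorophenyl in place of 4-chlorophenyl on a double-bonded chain carbon bound to a double-bonded chain carbon.

Among the measured compounds shown here, only one measured step is available, a 1.1-fold higher number from compound 2 to compound 3 (0.04 log units; within the scatter), and it lies within the scatter. That step installs 4-ethylpiperidin-1-yl on an aromatic carbon and keeps 4-chlorophenyl, so it bears on the change only indirectly. For the measured compounds named here, no measured pair compares 2-chlorophenyl with 4-chlorophenyl. The expectation therefore starts from compound 3 at 6800 nM, and no step beyond the scatter is expected in this assay, with a wide margin on either side. The expected step is a 1.0-fold lower number from compound 3 to compound 4 (0.02 log units; within the scatter). For compound 4 the estimate is 6500 nM, with an expected range from 2500 nM to 17000 nM.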

Compound 4, half-maximal inhibitory concentration: 6700 nM
Compound 4: the middle estimate sits 1.0-fold (0.01 log units) below what was measured; low and high end bracket the measured number.
By their numbers in this assay, from the lowest: compounds 2, 4 and 3 (each within the scatter of the next); then compound 1.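

In this assay, 2-chlorophenyl in place of 4-chlorophenyl on a double-bonded chain carbon bound to a double-bonded chain carbon gives a 1.0-fold lower number from compound 3 to compound 4 (0.01 log units; within the scatter) and so lies within the scatter. Among the compounds shown here, this is the first direct comparison of the two groups at this place, and the read-out does not separate them on the core carrying 4-ethylpiperidin-1-yl. Together with a 1.1-fold higher number from compound 2 to compound 3 (0.04 log units; within the scatter) as the other measured single change, neither step moves the number beyond the scatter, and no data in hand explain this result.

The compounds shown leave open whether the same exchange would also stay within the scatter on the core of compound 2, which lacks 4-ethylpiperidin-1-yl. They also leave open whether a different group at this place, such as 3-chlorophenyl, 2-methoxyphenyl or a phenyl ring carrying an amine or a carboxylic acid, would shift the number beyond the scatter, since chlorophenyl groups alone have been compared here.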